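Compound 4: a 3-methoxyphenyl group at the limit

The compounds below may be only part of what the source reports. "The series", "measured", "known", "first", "only" and "open" are said of these compounds alone.

In a functional assay on MCF cells (Homo sapiens) for antiproliferative activity, with a stated time of 72 h (a lower number here means a stronger inhibitor, a higher number a weaker inhibitor), compound 1 `OC[C@H]1O[C@@H](n2cnc3c(NCc4ccc(F)cc4)ncnc32)[C@H](O)[C@@H]1O` gives 21000 nM. Compound 2 `OC[C@H]1O[C@@H](n2cnc3c(NCc4cccc(Br)c4)ncnc32)[C@H](O)[C@@H]1O` gives only a limit of the assay, > 166000 nM. Compound 3 `Cc1ccc(CNc2ncnc3c2ncn3[C@@H]2O[C@H](CO)[C@@H](O)[C@H]2O)cc1` also gives only a limit, > 166000 nM. Compound 3 therefore has no number of its own and sits at the limit of > 166000 nM in this assay, at which 2 of the 3 values shown sit.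

Compound 4 `COc1cccc(CNc2ncnc3c2ncn3[C@@H]2O[C@H](CO)[C@@H](O)[C@H]2O)c1` carries 3-methoxyphenyl in place of 4-methylphenyl on a saturated chain carbon bound to a nitrogen on an aromatic ring.

Two measured steps show how much the aromatic group can matter: an at least 7.9-fold higher number from compound 1 to compound 2 (0.89 log units; beyond the scatter) and an at least 7.9-fold higher number from compound 1 to compound 3 (0.89 log units; beyond the scatter). On these data alone, both lie beyond the scatter, but both end at the limit, so their full size is unknown. Neither involves the new group. Going by the values given here, since the only comparison among compounds at the limit is a step that the two limits leave unreadable from compound 2 to compound 3, no clear step is expected in this assay. The estimated step is an at least 1.1-fold lower number from compound 3 to compound 4 (0.04 log units; that floor lies within the scatter). For compound 4 the expected value is 150000 nM, within an estimated range of 50000 nM to 400000 nM.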

Compound 4, half-maximal inhibitory concentration: > 166000 nM
Compound 4 gave a limit, no number; the forecaster's own chance of this, stated with the estimate: 65%; middle value at least 1.1-fold (0.04 log units) away from the limit.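

Compound 4 shows that a group carrying a hydrogen-bond acceptor, 3-methoxyphenyl, does not restore a measurable number at this position in this assay, where 4-methylphenyl and 3-bromophenyl had already failed to give one. Set against compound 1, the only compound with a real number, the change gives an at least 7.9-fold higher number from compound 1 to compound 4 (0.89 log units; beyond the scatter), and this is a floor rather than a full size. Three different aromatic groups now end at the same point, with compound 1 the one exception: the limit of > 166000 nM in this assay, at which 3 of the 4 values shown sit.

On these data alone, the steps among compound 2, compound 3 and compound 4 cannot be read, so any order among them remains unknown. As far as these compounds go, it also stays open whether the fluoro group itself or its place on the ring sets compound 1 apart, a question that 3-fluorophenyl or 4-chlorophenyl would help to settle.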